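Cyclohexyl amide replacing difluorophenyl amide: an open question

This account rests on a few compounds, and the source may have more. Where it says the series, first, only, none or still open, it means among the compounds named here.

The measured compounds:
compound 1, `O=C(c1ccccc1F)N1CC[C@H]1c1nc(-c2cccc(F)c2)no1`, 920 nM
compound 2, `O=C(c1ccc(F)c(F)c1)N1CC(c2nc(-c3cccc(F)c3)no2)C1`, > 10000 nM
compound 3, `Cc1ccc(S(=O)(=O)N2CC(c3nc(-c4cccc(Cl)c4)no3)C2)cc1`, 920 nM

In an assay on HEK293 cells for negative allosteric modulation of metabotropic glutamate receptor 5 (Homo sapiens), read by FLIPR (a lower number here means a stronger inhibitor, a higher number a weaker inhibitor), compound 1 gives 920 nM and compound 3 gives 920 nM, two values that lie within the scatter of each other. For compound 2 the assay reports only a limit, > 10000 nM. That limit is the one described by the limit of > 10000 nM in this assay, at which 1 of the 3 values shown sits, so compound 2 stands at the weak edge of what this assay can report, without a number of its own.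

Compound 4 is `CC1CCCCC1C(=O)N1CC(c2nc(-c3cccc(F)c3)no2)C1`. It differs from compound 2 in one place: 2-methylcyclohexyl in place of 3,4-difluorophenyl on a carbonyl carbon. Among the measured compounds shown here, no measured step connects two compounds that differ in this way, so the direction of the change rests on expectation alone. The estimate is a step of an at least 2.0-fold lower number from compound 2 to compound 4 (0.30 log units; that floor lies within the scatter), modest in size and uncertain in sign, since compound 2 itself offers only a limit as a starting point. Compound 4 is expected to give 5000 nM, in a range from 1200 nM to 20000 nM.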

Compound 4, half-maximal inhibitory concentration: > 10000 nM
Compound 4 gave a limit, no number; the forecaster's own chance of this, stated with the estimate: 40%; at least 2.0-fold (0.30 log units) between middle value and limit.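

In this assay compound 4 gives > 10000 nM, which is a limit and not a number. Compound 2 also stands at a limit, so no step from compound 2 to compound 4 can be read: the limit of > 10000 nM in this assay, at which 2 of the 4 values shown sit.

As far as these compounds go, whether 2-methylcyclohexyl in place of 3,4-difluorophenyl on a carbonyl carbon gives a stronger or a weaker inhibitor remains open.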